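This account rests on a few compounds, and the source may have more. Where it says the series, first, only, none or still open, it means among the compounds named here.

Four compounds built on one shared core were examined for their effect on the growth of a colon carcinoma line. In a functional assay on SW-620 cells (Homo sapiens) for antiproliferative activity, read by MTT assay, with a stated time of 72 h (a lower number here means a stronger inhibitor, a higher number a weaker inhibitor), compound 1 `CCCCCCc1cc2cn(Cc3cn(-c4ccccc4F)nn3)c(=O)nc2o1` gives only a limit of the assay, > 100000 nM. Compound 2 `O=c1nc2oc(CCCCl)cc2cn1Cc1cn(-c2ccccc2F)nn1` likewise gives only a limit in this assay, > 100000 nM. The change from compound 1 to compound 2 is chloro in place of propyl on a saturated chain carbon, three bonds along the chain from an aromatic carbon, and its step that the two limits leave unreadable from compound 1 to compound 2 has no readable size because both values sit at the limit of > 100000 nM in this assay, at which 2 of the 3 values shown sit. Going by the values given here, compound 3 `CCCCCCc1cc2cn(Cc3cn(Cc4ccccc4)nn3)c(=O)nc2o1` differs from compound 1 by benzyl in place of 2-fluorophenyl on an aromatic nitrogen; in this assay compound 3 gives 93500 nM, the only number among the three measured compounds, and the step of an at least 1.0-fold lower number from compound 1 to compound 3 (0.02 log units; that floor lies within the scatter) is merely a floor that lies within the usual scatter.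

Compound 4 `O=c1nc2oc(CCCCl)cc2cn1Cc1cn(Cc2ccccc2)nn1` has not yet been measured. It differs from compound 3 by chloro in place of propyl on a saturated chain carbon, three bonds along the chain from an aromatic carbon, the same change that separates compound 1 from compound 2, made at the same place on the core of compound 3 rather than the core of compound 1. The earlier instance of this change left its size unreadable, so the expectation for compound 4 rests chiefly on compound 3 giving 93500 nM. The step that this estimate for compound 4 implies is expected to be a 1.2-fold higher number from compound 3 to compound 4 (0.07 log units; within the scatter). Compound 4 is therefore expected to give about 110000 nM, with a likely range between 40000 nM and 300000 nM, and a substantial chance that the assay reports only a limit.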

Compound 4, half-maximal inhibitory concentration: 75500 nM
Beside the measured number, compound 4's estimate is 1.5-fold (0.16 log units) above it; the range from low to high includes it.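

In this assay, chloro in place of propyl gives a 1.2-fold lower number from compound 3 to compound 4 (0.09 log units; within the scatter), so on this core the change shows no difference beyond the usual scatter. Benzyl in place of 2-fluorophenyl on the aromatic nitrogen, carried to the chloro-bearing core, gives an at least 1.3-fold lower number from compound 2 to compound 4 (0.12 log units; that floor lies within the scatter), and the two instances of that change can be set side by side only as floors: the same change on two cores in this assay, an at least 1.0-fold lower number (0.02 log units; that floor lies within the scatter) from compound 1 to compound 3 and an at least 1.3-fold lower number (0.12 log units; that floor lies within the scatter) from compound 2 to compound 4; the limit leaves it open whether they differ. The chloro change between compound 1 and compound 2 cannot be read, so the series does not show whether that change carries over from one core to another, nor how large the benzyl change really is, and both questions stop at the same assay limit: the limit of > 100000 nM in this assay, at which 2 of the 4 values shown sit.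

The compounds shown leave open what an amine or a carboxylic acid at the end of the chain, or a longer chain than hexyl, would give in this assay. They also leave open whether a methoxy group on the benzyl, or a different group in its place on the aromatic nitrogen, would give a number that stands clear of the scatter.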